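The source may report more compounds than this note shows. Statements on the series, on what has been measured and on what is new or still open speak of the compounds shown alone.

Measured in an ADME assay on microsomes from liver (Homo sapiens) for metabolic stability; a higher number here means faster removal of the compound, a lower number slower removal:
- compound 1 `Cn1ncc(-c2nn(C)c3ncnc(N4CCC4)c23)c1-c1ccc(C2CC2)cc1`: 90 mL/min/kg
- compound 2 `Cn1ncc(-c2nn(C)c3ncnc(N4CCC4)c23)c1-c1ccccc1`: 34 mL/min/kg

Compound 2 has the lower of the two numbers in this assay. Compound 3 `Cn1ncc(-c2nn(C)c3ncnc(N4CCC4)c23)c1-c1ccc(C2CC2)cn1` differs from it as follows: 5-cyclopropylpyridin-2-yl in place of phenyl on an aromatic carbon. In words, 5-cyclopropylpyridin-2-yl stands in place of phenyl on an aromatic carbon. Going by the values given here, the one relevant measured step is a 2.6-fold lower number from compound 1 to compound 2 (0.42 log units; beyond the scatter), a modest step; read in reverse, it points upward for the gain of cyclopropyl. Among the compounds with values here, no measured step isolates the ring nitrogen, so a smaller upward step is assumed, possibly within the scatter. The expected change is a 1.5-fold higher number from compound 2 to compound 3 (0.17 log units; within the scatter). For compound 3 the estimated value is 50 mL/min/kg, with an expected range of 28 mL/min/kg to 90 mL/min/kg.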

Compound 3, clearance: 53 mL/min/kg
Compound 3: the middle estimate sits 1.1-fold (0.03 log units) below what was measured; the measured number falls inside the stated range.
By their numbers in this assay, from the lowest: compounds 2, 3 and 1 (each within the scatter of the next, the first and the last beyond it).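

In this assay, exchanging 4-cyclopropylphenyl for 5-cyclopropylpyridin-2-yl gives a 1.7-fold lower number from compound 1 to compound 3 (0.23 log units; within the scatter), so the ring nitrogen has no readable effect in this cyclopropyl-bearing group. Replacing phenyl with 5-cyclopropylpyridin-2-yl gives a 1.6-fold higher number from compound 2 to compound 3 (0.19 log units; within the scatter), which also leaves compound 3 unresolved from compound 2, even though compound 1 and compound 2 stand apart. Nothing available explains these numbers.

Still open, going by these compounds, is how an unsubstituted pyridin-2-yl group would read in this assay, with no cyclopropyl present. Also open, on these data alone, is whether an amine or a longer chain in place of cyclopropyl would shift the number beyond the scatter.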